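Thiophene for Phenyl on the Pyridine Carbon of Compound 2

The source may report more compounds than this note shows. Statements on the series, on what has been measured and on what is new or still open speak of the compounds shown alone.

Compound 1 `Oc1cccc(-c2cc(-c3ccc(Cl)cc3)nc(-c3ccsc3)c2)c1` gives 8850 nM in a functional assay on HCT-15 cells (Homo sapiens) for cytotoxicity, read by CCK-8 assay and cell counting, with a stated time of 2 days; on this read-out lower numbers stand for stronger inhibition and higher numbers for weaker inhibition. Compound 2 `Oc1cccc(-c2cc(-c3ccccc3)nc(-c3ccccc3Cl)c2)c1` gives 2930 nM in this assay.

Compound 2 holds the lower of the two numbers; compound 1 stands beyond the scatter above it. Compound 3 `Oc1cccc(-c2cc(-c3ccsc3)nc(-c3ccccc3Cl)c2)c1` differs from compound 2 by thiophen-3-yl in place of phenyl on an aromatic carbon. Among the measured compounds shown here, no step of this kind between measured compounds is available, so the direction is uncertain. A small step toward weaker inhibition, close to the scatter, is expected, a 1.3-fold higher number from compound 2 to compound 3 (0.11 log units; within the scatter). For compound 3 the estimated value in this assay is 3800 nM, within the range 1300 nM to 11000 nM.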

Compound 3, half-maximal inhibitory concentration: 2500 nM
Compound 3: middle estimate off by 1.5-fold (0.18 log units), on the high side, within the range that was stated.
By their numbers in this assay, from the lowest: compounds 3 and 2 (each within the scatter of the next); then compound 1.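

In this assay, thiophen-3-yl in place of phenyl on the aromatic carbon next to the ring nitrogen gives a 1.2-fold lower number from compound 2 to compound 3 (0.07 log units; within the scatter) and so leaves the number unmoved beyond the scatter. Moving to the other group, 2-chlorophenyl in place of 4-chlorophenyl gives a 3.5-fold lower number from compound 1 to compound 3 (0.55 log units; beyond the scatter) and is the only step shown that passes the scatter. Nothing given here accounts for either step. Still open, going by these compounds, is whether a non-aromatic group on this carbon, such as an amine or a carboxylic acid, would hold the number as thiophen-3-yl does.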